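Replacing azido with methoxy in compound 1

A few compounds are considered here, and "the series" means these few. Any claim that something is new, unique, unknown or untested is made for them only; others in the source may bear on it.

Measured in a functional assay on MGC-803 cells (Homo sapiens) for antiproliferative activity, read by MTT assay, with a stated time of 48 h; on this read-out higher numbers stand for weaker inhibition and lower numbers for stronger inhibition:
- compound 1 `COc1ccc(CN(C(=O)CSc2nc3ccccc3s2)c2cc(OC)c(OC)c(OC)c2)cc1N=[N+]=[N-]`: 187 nM
- compound 2 `COc1cc(N(Cc2ccccc2)C(=O)CSc2nc3ccccc3s2)cc(OC)c1OC`: 44300 nM

Compound 1 holds the lower of the two numbers. Compound 3 `COc1ccc(CN(C(=O)CSc2nc3ccccc3s2)c2cc(OC)c(OC)c(OC)c2)cc1OC` differs from it in one place: methoxy in place of azido on an aromatic carbon. In words, methoxy stands in place of azido on an aromatic carbon, turning 3-azido-4-methoxybenzyl into 3,4-dimethoxybenzyl. Within the data shown here, one measured step bears on this: a 240-fold higher number from compound 1 to compound 2 (2.37 log units; beyond the scatter), large and beyond the scatter, with phenyl in place of the whole 3-azido-4-methoxyphenyl. Among the measured compounds shown here, that step removes azido and methoxy together, and no measured pair isolates the azido. For the measured compounds named here, with a 240-fold higher number from compound 1 to compound 2 (2.37 log units; beyond the scatter) as the only guide, a rise in this assay is expected, smaller than that step, as compound 3 keeps a group at that place. The estimated step is an 11-fold higher number from compound 1 to compound 3 (1.03 log units; beyond the scatter). For compound 3 the estimated value is 2000 nM, with an expected range from 250 nM to 20000 nM.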

Compound 3, half-maximal inhibitory concentration: 34100 nM
For compound 3 the middle estimate is 17-fold (1.23 log units) below the measured one; measured number above the stated range.
By their numbers in this assay, from the lowest: compound 1; then compounds 3 and 2 (each within the scatter of the next).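

In this assay, the azido group at this aromatic carbon, ortho to a methoxy group, proves decisive on its own: methoxy in its place gives a 180-fold higher number from compound 1 to compound 3 (2.26 log units; beyond the scatter). Keeping a group of similar heavy-atom count at that carbon therefore does not preserve the low number of compound 1, and a 1.3-fold lower number from compound 2 to compound 3 (0.11 log units; within the scatter) shows that 3,4-dimethoxyphenyl and phenyl are not separated in this assay. No measurement here explains why azido differs so sharply from methoxy at this position.

Open, as far as these compounds go, is whether an amino group, a nitrile or a chlorine at this carbon would keep the number near that of compound 1 or match compound 3. Also open, from the compounds shown here alone, is whether azido holds that level once the neighbouring 4-methoxy group is replaced by hydrogen.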